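The source may hold more compounds than are shown below. What is called first, only, known or untested is meant among the compounds shown, and "the series" means these compounds.

Measured in a functional assay on the whole organism for inhibition, with Mus musculus as the target, at a dose of 10 mg/kg by the oral route; a higher number here means more inhibition at the dose given (going by the name of the read-out), a lower number less inhibition:
compound 1 `COc1cccc(N(C)/C(S)=C2/C(=O)c3cc(Cl)ccc3N(C)C2=O)c1`: compound 1 gives 30%
compound 2 `CN1C(=O)/C(=C(/S)N(C)c2ccc(F)c(F)c2)C(=O)c2cc(Cl)ccc21`: compound 2 gives 62%
compound 3 `CN1C(=O)/C(=C(/S)N(C)c2cccc(Cl)c2)C(=O)c2cc(Cl)ccc21`: compound 3 gives 63%

Compound 3 stands highest of the three numbers, but compound 2 sits within the scatter of it, a number 1 percentage points higher from compound 2 to compound 3 (within the scatter), so no order between those two is claimed; compound 1 lies well apart, a number 33 percentage points higher from compound 1 to compound 3 (beyond the scatter). Compound 4 `CN1C(=O)/C(=C(/S)N(C)c2ccc(Br)cc2)C(=O)c2cc(Cl)ccc21` differs from compound 3 by 4-bromophenyl in place of 3-chlorophenyl on an amine nitrogen. The step that bears most directly is a number 1 percentage points higher from compound 2 to compound 3 (within the scatter), where one halogenated phenyl replaced another without a change beyond the scatter. The large steps of a number 32 percentage points higher from compound 1 to compound 2 (beyond the scatter) and a number 33 percentage points higher from compound 1 to compound 3 (beyond the scatter) both involve the methoxy leaving, which is not the case here. Among the compounds with values here, no measured step exchanges a halogen for a halogen at a different place on the phenyl. A step of a number 5 percentage points lower from compound 3 to compound 4 (within the scatter) in this assay is therefore expected, within the scatter. Compound 4 is estimated at 58%, range 40% to 75%.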

Compound 4, a percentage reported as inhibition, in the whole organism at one dose (the size of the read-out at that dose, not a potency): 50%
Beside the measured number, compound 4's estimate is 8 percentage points above it, within the range that was stated.
By their numbers in this assay, from the lowest: compound 1; then compound 4; then compounds 2 and 3 (each within the scatter of the next).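

In this assay, exchanging one halogenated phenyl on the amine nitrogen for another can matter: 4-bromophenyl in place of 3-chlorophenyl gives a number 13 percentage points lower from compound 3 to compound 4 (beyond the scatter), and in place of 3,4-difluorophenyl it gives a number 12 percentage points lower from compound 2 to compound 4 (beyond the scatter), whereas the exchange between those two groups stayed within the scatter. 4-Bromophenyl in place of 3-methoxyphenyl still gives a number 20 percentage points higher from compound 1 to compound 4 (beyond the scatter). Nothing available explains these steps. Still open, going by these compounds, is whether the halogen or its ring position drives the step, which 4-chlorophenyl and 3-bromophenyl would separate.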